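Trimming a naphthyl amide to phenyl in a transporter series

The source may report more compounds than this note shows. Statements on the series, on what has been measured and on what is new or still open speak of the compounds shown alone.

Two compounds share a core, compound 1 `CC(=O)OCCSC[C@H]1CN(C)CC[C@H]1c1ccc(Cl)cc1` and compound 2 `CN1CC[C@@H](c2ccc(Cl)cc2)[C@@H](CSCC(=O)Nc2cccc3ccccc23)C1`. In an assay on a subcellular fraction from brain with Norepinephrine transporter (Rattus norvegicus) as the target (on this read-out higher numbers stand for weaker inhibition and lower numbers for stronger inhibition), compound 1 gives 610 nM, and compound 2 gives 101 nM. Compound 2 thus has the lower of the two numbers, and the gap between compound 2 and compound 1 is wide enough to lie beyond the usual scatter of repeated measurements.

Compound 3 `CN1CC[C@@H](c2ccc(Cl)cc2)[C@@H](CSCC(=O)Nc2ccccc2)C1` has not yet been measured in this assay. It differs from compound 2 in one place, phenyl in place of naphthalen-1-yl on an amide-type nitrogen. Going by the values given here, no pair of measured compounds shows this change, so nothing measured tells how the assay responds to it. Since the only data are the two values of compound 1 and compound 2, the expectation for compound 3 rests on the value of compound 2 alone, with a modest step toward a higher number expected, as a 2.5-fold higher number from compound 2 to compound 3 (0.39 log units; beyond the scatter). Compound 3 is therefore estimated at 250 nM, with a likely range from 80 nM to 800 nM.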

Compound 3, inhibition constant: 1060 nM
The estimate for compound 3 lay 4.2-fold (0.63 log units) below the measured number; the measured number lies above the stated range.
By their numbers in this assay, from the lowest: compound 2; then compounds 1 and 3 (each within the scatter of the next).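

In this assay, the group on the amide-type nitrogen proves to be a sensitive point: phenyl in place of naphthalen-1-yl gives a 10-fold higher number from compound 2 to compound 3 (1.02 log units; beyond the scatter). The earlier compounds shown here gave no reading of any change at this place, and this step shows that the second six-membered aromatic ring of naphthalen-1-yl cannot be given up without a large loss of inhibition in this read-out, since the two groups have the same counts of hydrogen-bond donors, hydrogen-bond acceptors and net charge and differ in their carbon atoms and that ring. Nothing available explains why the number rises by so much.

From the compounds shown here alone, with only these two groups compared on that nitrogen, it remains open whether the reading depends on the second aromatic ring itself or simply on the size of the group, a question that a cyclohexyl or a benzyl group there would help to answer. Going by these compounds, it is also open whether the step would keep its size if a fluorine replaced the chlorine on the shared core.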